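Naphthalen-2-yl for phenyl on the five-membered ring

This account rests on a few compounds, and the source may have more. Where it says the series, first, only, none or still open, it means among the compounds named here.

Compound 1 `Cc1ccc2nc(Cl)c(/C=N/n3cc(-c4ccccc4)nc3N)cc2c1` is the reference point of this pair. In a functional assay on HCT-116 cells (Homo sapiens) for cytotoxicity, read by MTT assay, with a stated time of 48 h (on this read-out higher numbers stand for weaker inhibition and lower numbers for stronger inhibition), compound 1 gives 7120 nM, the upper of the two numbers recorded so far, though the gap to its neighbour stays within the scatter. For the measured compounds named here, compound 2 `Nc1nc(-c2cccc3ccccc23)cn1/N=C/c1cc2ccccc2nc1Cl` differs from compound 1 in more than one place, so no single step connects them; in this assay compound 2 gives 6340 nM, and the two values are not distinguishable. Compound 3 `Cc1ccc2nc(Cl)c(/C=N/n3cc(-c4ccc5ccccc5c4)nc3N)cc2c1` is the next member. Relative to compound 1 the change is naphthalen-2-yl in place of phenyl on an aromatic carbon. Going by the values given here, no step between two measured compounds isolates this change, and the values of compound 1 and compound 2 give no hint of a shift in either direction. The expected step of a 1.2-fold lower number from compound 1 to compound 3 (0.07 log units; within the scatter) is therefore none beyond the scatter. For compound 3 in this assay the estimate is 6000 nM, with a range from 2500 nM to 14000 nM.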

Compound 3, half-maximal inhibitory concentration: 27400 nM
Estimate against measurement, compound 3: 4.6-fold (0.66 log units) below; measured number above the stated range.
By their numbers in this assay, from the lowest: compounds 2 and 1 (each within the scatter of the next); then compound 3.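

In this assay the aromatic carbon of the five-membered ring, next to the ring nitrogen, is not indifferent to the group it carries: naphthalen-2-yl in place of phenyl gives a 3.8-fold higher number from compound 1 to compound 3 (0.59 log units; beyond the scatter) and so weakens inhibition. For the compounds shown here, this is the first step that isolates a single place, and it shows that the second six-membered aromatic ring of naphthalen-2-yl is not accepted here without a loss, though the step is modest and rests on one pair. Going by these compounds alone, nothing measured so far accounts for the shift.

As far as these compounds go, whether a methyl group at this carbon, or a phenyl ring bearing an amine or a carboxylic acid, would move the number in either direction remains open. So does the effect of replacing the amino group on the same ring with a methylamino group.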